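This account rests on a few compounds, and the source may have more. Where it says the series, first, only, none or still open, it means among the compounds named here.

Three compounds built on one shared core were tested in a functional assay on PC-3 cells (Homo sapiens) for antiproliferative activity, with a stated time of 48 h; a higher number here means a weaker inhibitor, a lower number a stronger inhibitor. Compound 1 `CCN(CC)c1ccc(-c2cccc(C#N)c2)nn1` reaches only the limit of the assay, > 25000 nM, so no number is known for it. Compound 2 `CCN(CC)c1ccc(-c2ccc(C#N)cc2)nn1`, made of the same atoms joined differently, also stops at the assay limit > 25000 nM. How the two cores differ is not broken down here. Compound 3 `CCOC(=O)c1ccc(-c2ccc(N(CC)CC)nn2)cc1` gives 1000 nM. Compound 3 arises from compound 2 by ethoxycarbonyl in place of cyano on an aromatic carbon, and this change made an at least 25-fold lower number from compound 2 to compound 3 (1.39 log units; beyond the scatter), a step that can be set only as a bound due to the limit of > 25000 nM in this assay, at which 2 of the 3 values shown sit. Compound 4 `CCOC(=O)c1cccc(-c2ccc(N(CC)CC)nn2)c1` has not yet been measured. It arises from compound 1 by ethoxycarbonyl in place of cyano on an aromatic carbon, the same kind of change as before, though the incoming group now sits meta to a large group where earlier it sat para to a large group. The expected step is an at least 10-fold lower number from compound 1 to compound 4 (1.00 log units; beyond the scatter). This expectation rests on the step from compound 2 to compound 3 and on compound 1 sitting at the assay limit > 25000 nM. Compound 4 is estimated at 2500 nM, with a likely range from 600 nM to 15000 nM, unless it too remains at the limit.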

Compound 4, half-maximal inhibitory concentration: > 25000 nM
Compound 4: no number, only a limit; the forecaster's own chance of this, stated with the estimate: 25%; middle value at least 10-fold (1.00 log units) away from the limit.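

Compound 4 gives only a limit, > 25000 nM, and not a number, and compound 1 likewise gives only a limit, so no step between them can be read: the limit of > 25000 nM in this assay, at which 3 of the 4 values shown sit.

The compounds shown leave open whether ethoxycarbonyl in place of cyano changes the number at all when the group sits meta to a large group.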